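The source may hold more compounds than are shown below. What is called first, only, known or untested is meant among the compounds shown, and "the series" means these compounds.

In a functional assay on HCT-116 cells (Homo sapiens) for antiproliferative activity, read by CCK-8 assay, with a stated time of 72 h (a lower number here means a stronger inhibitor, a higher number a weaker inhibitor), compound 1 `COc1ccc(SCc2ccc(C(=O)Nc3ccccc3N)cc2)cc1` gives 1640 nM and compound 3 `COc1ccc(SCc2ccc(C(=O)Nc3ccccc3N)cc2)cc1OC` gives 2000 nM, two values within the scatter of each other. For compound 2 `Nc1ccccc1NC(=O)/C=C/c1ccc(CSc2ccc(F)cc2)cc1` the record reads "not determined" (no result reported), so it offers no comparison. Compound 4 `Nc1ccccc1NC(=O)c1ccc(CSCCc2ccccc2)cc1` differs from compound 1 by phenethyl in place of 4-methoxyphenyl on a sulfur. Among the compounds with values here, the one measured step, a 1.2-fold higher number from compound 1 to compound 3 (0.09 log units; within the scatter), adds methoxy in place of hydrogen on an aromatic carbon and bears only indirectly, since no measured step replaces the whole group on sulfur. No shift beyond the scatter is therefore expected, though with wide uncertainty. The expected step is a 1.1-fold higher number from compound 1 to compound 4 (0.04 log units; within the scatter). Compound 4 is estimated at 1800 nM, with an expected range of 700 nM to 4500 nM.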

Compound 4, half-maximal inhibitory concentration: 2810 nM
Beside the measured number, compound 4's estimate is 1.6-fold (0.19 log units) below it; low and high end bracket the measured number.
By their numbers in this assay, from the lowest: compounds 1, 3 and 4 (each within the scatter of the next).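

In this assay the whole group on sulfur can be exchanged with the step staying inside the scatter: phenethyl in place of 4-methoxyphenyl gives a 1.7-fold higher number from compound 1 to compound 4 (0.23 log units; within the scatter) and this holds with the hydrogen-bond acceptor of the leaving group gone and the heavy-atom count unchanged. Within the data shown here, the earlier step changed only a methoxy on the aromatic ring, so this is the first reading on the entire group. No supporting measurement explains the result.

Still open, from the compounds shown here alone, is whether the number holds with a group on sulfur lacking an aromatic ring, such as a hexyl chain. An amine or a carboxylic acid at the end of the phenethyl chain is equally untested here.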